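A few compounds are considered here, and "the series" means these few. Any claim that something is new, unique, unknown or untested is made for them only; others in the source may bear on it.

In a functional assay on PC-3 cells (Homo sapiens) for cytotoxicity, read by sulforhodamine B assay (a lower number here means that less compound is tolerated, a higher number that more compound is tolerated), compound 3 `COc1cccc(OC)c1OCCNCCOc1ccccc1OCc1ccc(C)cc1` gives 61700 nM, the highest of the three numbers shown, although compound 1 `COc1cccc(OC)c1OCCNCCOc1ccccc1OCc1ccccc1Cl` with 58900 nM and compound 2 `COc1cccc(OC)c1OCCNCCOc1ccccc1OCc1cccc(Cl)c1` with 58900 nM both sit within the scatter of it. The step from compound 3 to compound 4 `COc1cccc(OC)c1OCCNCCOc1ccccc1OCc1ccc(OC(C)C)cc1` is isopropoxy in place of methyl on an aromatic carbon. The measured steps that touch the same part of the shared core are no change at the digits printed from compound 1 to compound 2 (within the scatter), a 1.0-fold higher number from compound 1 to compound 3 (0.02 log units; within the scatter) and a 1.0-fold higher number from compound 2 to compound 3 (0.02 log units; within the scatter), every one of them within the scatter. On that basis the change is expected to leave this assay essentially unchanged, with no step beyond the scatter, so the expected step is a 1.0-fold lower number from compound 3 to compound 4 (0.01 log units; within the scatter). Compound 4 is therefore estimated at 60000 nM, with a range from 30000 nM to 120000 nM.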

Compound 4, concentration lethal to 50% of the cells: 63100 nM
Estimate against measurement, compound 4: 1.1-fold (0.02 log units) below; low and high end bracket the measured number.
By their numbers in this assay, from the lowest: compounds 1, 2, 3 and 4 (each within the scatter of the next).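

In this assay, isopropoxy in place of methyl on an aromatic carbon gives a 1.0-fold higher number from compound 3 to compound 4 (0.01 log units; within the scatter) and so extends the tolerated changes at this position from chloro and methyl to a larger, oxygen-linked group, still without a step beyond the scatter. The comparisons with the chlorophenyl compounds agree, with a 1.1-fold higher number from compound 2 to compound 4 (0.03 log units; within the scatter) and a 1.1-fold higher number from compound 1 to compound 4 (0.03 log units; within the scatter). No evidence is available to explain this result. On these data alone, whether an amine, a carboxylic acid or a longer chain here would give a step beyond the scatter remains open. So does the effect of changes elsewhere on the shared core.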